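The compounds below may be only part of what the source reports. "The series", "measured", "known", "first", "only" and "open" are said of these compounds alone.

Compound 1, with the structure `NC(=O)/C=C1\CCc2c(F)cccc21`, and compound 2, with the structure `CC(C)NC(=O)/C=C1\CCc2ccc(F)cc21`, were both tested in a functional assay on the whole organism with Rattus norvegicus as the target, at a dose of 20 mg/kg by the oral route; on this read-out lower numbers stand for less inhibition and higher numbers for more inhibition at the one dose given (going by the name of the read-out). In this assay compound 1 gives 40%. In this assay compound 2 gives 45%. These two numbers sit within the usual scatter of each other, so compound 2 cannot be told apart from compound 1 on this read-out. Compound 3, with the structure `CCN(C)C(=O)/C=C1\CCc2ccc(F)cc21`, has not yet been measured in this assay. It differs from compound 2 in one place: ethyl(methyl)amino in place of isopropylamino on a carbonyl carbon. Among the compounds with values here, no step between measured compounds is known here, so the size of this change cannot be read from a pair. No step beyond the scatter is expected. Compound 3 is therefore estimated at 40% in this assay, with a likely range from 20% to 60%. This estimate means an expected step of a number 5 percentage points lower from compound 2 to compound 3 (within the scatter), within the scatter.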

Compound 3, a percentage reported as inhibition, in the whole organism at one dose (the size of the read-out at that dose, not a potency): 20%
For compound 3 the middle estimate is 20 percentage points above the measured one; low and high end bracket the measured number.
By their numbers in this assay, from the lowest: compound 3; then compounds 1 and 2 (each within the scatter of the next).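

The swap on the carbonyl carbon leaves the atoms unchanged and only joins them differently, yet in this assay it gives a number 25 percentage points lower from compound 2 to compound 3 (beyond the scatter), so this position is sensitive to a change of this kind. The change also removes the amide hydrogen: isopropylamino carries a hydrogen-bond donor and ethyl(methyl)amino carries none, and this single step cannot separate the loss of that hydrogen from the rearrangement of the carbons. Nothing measured here explains the drop.

An ethylamino or a dimethylamino group on the same carbonyl carbon could help separate those two differences, as one keeps the amide hydrogen and the other does not. From the compounds shown here alone, whether the same swap gives a similar step on the core of compound 1 also remains open.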